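This account rests on a few compounds, and the source may have more. Where it says the series, first, only, none or still open, it means among the compounds named here.

In a functional assay on MIA PaCa-2 cells (Homo sapiens) for inhibition, read by MTT assay, with a stated time of 72 h (on this read-out lower numbers stand for stronger inhibition of growth and higher numbers for weaker inhibition of growth), three compounds have been measured. Compound 1 `COc1ccc(CNCCCNS(=O)(=O)c2cc(C(F)(F)F)cc(C(F)(F)F)c2)cc1OC` gives 2800 nM, the lowest of the three numbers. Compound 2 `O=S(=O)(NCCCCCCNCc1ccc(Br)cc1)c1ccc2c(c1)OCC2` gives 13000 nM, and compound 3 `O=S(=O)(NCCCCCCNCc1ccc(Br)cc1)c1ccc2ccsc2c1` gives 6000 nM. Among the compounds with values here, the only step between measured compounds that differ in one place is a 2.2-fold lower number from compound 2 to compound 3 (0.34 log units; beyond the scatter), a change on the sulfonyl sulfur, far from where compound 4 differs.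

Compound 4 `COc1cccc(CNCCCNS(=O)(=O)c2cc(C(F)(F)F)cc(C(F)(F)F)c2)c1` differs from compound 1 by hydrogen in place of methoxy on an aromatic carbon. Within the data shown here, no measured step concerns a change of this kind, so nothing here shows how removing a methoxy group at that place moves the number in this assay. The step from compound 2 to compound 3, which swaps the group on the sulfonyl sulfur, cannot be carried over to this change. With no direct guide, the expectation is a step within the usual scatter, in no preferred direction, so that compound 4 is estimated at 3500 nM, with a range from 1400 nM to 9000 nM, which amounts to an expected step of a 1.3-fold higher number from compound 1 to compound 4 (0.10 log units; within the scatter).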

Compound 4, concentration for 50% growth inhibition: 3400 nM
Estimate against measurement, compound 4: 1.0-fold (0.01 log units) above; low and high end bracket the measured number.
By their numbers in this assay, from the lowest: compounds 1, 4 and 3 (each within the scatter of the next, the first and the last beyond it); then compound 2.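

In this assay, removing the methoxy group that lies ortho to a methoxy group and para to a large group turns 3,4-dimethoxybenzyl into 3-methoxybenzyl and gives a 1.2-fold higher number from compound 1 to compound 4 (0.08 log units; within the scatter), a step that stays within the scatter. Within the data shown here, this is the first reading at this place on the ring, as the earlier step concerned only the group on the sulfonyl sulfur, and it shows that this methoxy group can be replaced by hydrogen with no measurable change in the number. Nothing measured here explains why this swap makes so little difference.

The compounds shown leave open whether the remaining methoxy group can also be removed, and what an amine, a hydroxyl group or a fluorine atom at the vacated place would do to the number. They also leave open whether removing this methoxy group would give a similar step with a different group on the sulfonyl sulfur.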